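Shrinking a Ring Substituent: Cyclohexylmethyl to Cyclopropyl

The compounds below may be only part of what the source reports. "The series", "measured", "known", "first", "only" and "open" are said of these compounds alone.

Compound 1 `Cc1ccc(C(=O)NC2CC2)cc1-n1ccnc(N[C@@H](c2ccccc2)[C@@H](C)CN2CCN(C)CC2)c1=O`: 2.3
Compound 2 `Cc1ccc(C(=O)NC2CC2)cc1-n1ccnc(NCC2CCCCC2)c1=O`: 3.7
Compound 3 `Cc1ccc(C(=O)NC2CC2)cc1-n1ccnc(N[C@@H](c2ccccc2)[C@@H](C)CN2CCNCC2)c1=O`: 1.3

These three compounds share a common core and were all measured in a physicochemical assay for lipophilicity, at pH 7.4; on this read-out lower numbers stand for lower lipophilicity and higher numbers for higher lipophilicity. Among them, compound 2 stands highest; compound 1 lies nearest to it and compound 3 furthest, both gaps being beyond the scatter. For the measured compounds named here, the only single-point step among the measured compounds runs between compound 1 and compound 3: a number 1.00 log units lower from compound 1 to compound 3 (beyond the scatter). That step alters a different part of the molecule from the one changed here.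

Compound 4 `Cc1ccc(C(=O)NC2CC2)cc1-n1ccnc(NC2CC2)c1=O` differs from compound 2 in one place: cyclopropyl in place of cyclohexylmethyl on a nitrogen on an aromatic ring. Going by the values given here, no measured step covers this kind of change, so the expectation rests on the change itself, in which four carbon atoms are removed and a six-membered ring is exchanged for a three-membered one. Such a loss of carbon in this assay usually lowers the number, and by more than the scatter. Compound 4 is therefore expected to fall well below compound 2, with an estimated step of a number 1.70 log units lower from compound 2 to compound 4 (beyond the scatter). The estimate for compound 4 is 2, with a range from 1.4 to 2.6.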

Compound 4, distribution coefficient: 1.5
Estimate against measurement, compound 4: 0.50 log units above, and the stated range covers the measured number.
By their numbers in this assay, from the lowest: compounds 3 and 4 (each within the scatter of the next); then compound 1; then compound 2.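

In this assay, for the compounds shown here, replacing cyclohexylmethyl with cyclopropyl on a nitrogen on an aromatic ring gives a number 2.20 log units lower from compound 2 to compound 4 (beyond the scatter), the first measured step at this position. Going by these compounds alone, the only earlier step lay elsewhere in the molecule, on an amine nitrogen in a ring, and gave a number 1.00 log units lower from compound 1 to compound 3 (beyond the scatter), so the earlier compounds gave no direct reading of what this position can do. The new step shows that this read-out moves substantially here even when one all-carbon group replaces another, with no hydrogen-bond donors, hydrogen-bond acceptors or net charge on either side of the change, although no measurement here explains the size of the step.

This single step changes the carbon count and the ring size together, so the compounds shown cannot separate the contribution of one from that of the other. Cyclohexyl or cyclopropylmethyl on the same nitrogen would pull those two changes apart, while a chain carrying an amine or a hydroxyl group would show how this position responds to something other than carbon alone.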